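From 2-chloro-4-fluorophenyl to 4-methoxyphenyl on the shared core

This account rests on a few compounds, and the source may have more. Where it says the series, first, only, none or still open, it means among the compounds named here.

Measured in a functional assay on PC-3 cells (Homo sapiens) for cytotoxicity, read by MTT assay, with a stated time of 72 h; on this read-out higher numbers stand for weaker inhibition and lower numbers for stronger inhibition:
Compound 1 `CNC(=O)c1cc(Oc2ccc(C(=O)/C=C/c3ccco3)cc2)ccn1` gives "not determined" (no result reported)
Compound 2 `CNC(=O)c1cc(Oc2ccc(C(=O)/C=C/c3ccc([N+](=O)[O-])cc3)cc2)ccn1` gives 11100 nM
Compound 3 `CNC(=O)c1cc(Oc2ccc(C(=O)/C=C/c3ccc(F)cc3Cl)cc2)ccn1` gives 4760 nM

For the measured compounds named here, compound 3 holds the lower of the only two numbers, and compound 1 offers no number for comparison. The next structure is compound 4 `CNC(=O)c1cc(Oc2ccc(C(=O)/C=C/c3ccc(OC)cc3)cc2)ccn1`, and its change from compound 3 is 4-methoxyphenyl in place of 2-chloro-4-fluorophenyl on a double-bonded chain carbon bound to a double-bonded chain carbon. Going by the values given here, only one measured step bears on this place in this assay, namely a 2.3-fold lower number from compound 2 to compound 3 (0.37 log units; beyond the scatter), and it is modest. With a single step as a guide, no clear shift beyond the scatter is expected, though a slight rise seems likelier than a fall. The expected change is a 1.5-fold higher number from compound 3 to compound 4 (0.17 log units; within the scatter) as an estimate. For compound 4 the estimated value is 7000 nM, with an expected range from 2500 nM to 18000 nM.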

Compound 4, half-maximal inhibitory concentration: > 50000 nM
Compound 4: a limit, no number (the forecaster's own chance of this, stated with the estimate: 5%); at least 7.1-fold (0.85 log units) between middle value and limit.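

Compound 4 stands at a limit of the assay and not at a number: the limit of > 50000 nM in this assay, at which 1 of the 4 values shown sits. For the compounds shown here, at this place, a change of the aromatic group can do far more than the one earlier step suggested: 4-methoxyphenyl in place of 2-chloro-4-fluorophenyl brings an at least 10-fold higher number from compound 3 to compound 4 (1.02 log units; beyond the scatter), and methoxy in place of nitro on an aromatic carbon brings an at least 4.5-fold higher number from compound 2 to compound 4 (0.65 log units; beyond the scatter). Compound 4 thus lies on the weak side of both compounds with numbers.

The compounds shown leave open whether the chlorine or the fluorine of compound 3 accounts for its lower number. Where an amine on the aromatic ring would fall also remains open.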